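Aryl-triazole variants of the spiro-oxindole series: distal ring changes

The compounds below may be only part of what the source reports. "The series", "measured", "known", "first", "only" and "open" are said of these compounds alone.

Measured compounds:
compound 1 `N#CC1=C(N)Oc2c(c3nc4ccccc4nc3c3ccccc23)C12C(=O)N(Cc1cnnn1-c1cccc(Cl)c1)c1ccccc12` — 32600 nM
compound 2 `N#CC1=C(N)Oc2c(c3nc4ccccc4nc3c3ccccc23)C12C(=O)N(Cc1cnnn1-c1ccc([N+](=O)[O-])cc1)c1ccccc12` — > 50000 nM (a limit of the assay)
compound 3 `Cc1ccc(Cl)cc1-n1nncc1CN1C(=O)C2(C(C#N)=C(N)Oc3c2c2nc4ccccc4nc2c2ccccc32)c2ccccc21` — > 50000 nM (a limit of the assay)

In a functional assay on A549 cells (Homo sapiens) for antiproliferative activity, read by MTT assay, with a stated time of 48 h (a lower number here means a stronger inhibitor, a higher number a weaker inhibitor), compound 1 gives 32600 nM. For compound 2 the value > 50000 nM is a limit of the assay and not a number. For compound 3 the value > 50000 nM is likewise a limit and not a number. Compound 3 therefore stands at the ceiling of the series, alongside one other entry, as shown by the limit of > 50000 nM in this assay, at which 2 of the 3 values shown sit. The steps read: an at least 1.5-fold higher number from compound 1 to compound 2 (0.18 log units; that floor lies within the scatter), an at least 1.5-fold higher number from compound 1 to compound 3 (0.18 log units; that floor lies within the scatter), and a step that the two limits leave unreadable from compound 2 to compound 3.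

Compound 4 `N#CC1=C(N)Oc2c(c3nc4ccccc4nc3c3ccccc23)C12C(=O)N(Cc1cnnn1-c1cc(Cl)ccc1Cl)c1ccccc12` differs from compound 3 by chloro in place of methyl on an aromatic carbon, the 5-chloro-2-methylphenyl on the aromatic nitrogen becoming 2,5-dichlorophenyl. Among the compounds with values here, the only step touching this ring with a readable floor is the one from compound 1 to compound 3, where methyl in place of hydrogen moved the number from a measured value to the limit; the change from compound 2 to compound 3 is unreadable. Within the data shown here, nothing among the measured steps resolves a difference between chloro and methyl at this carbon, so no step beyond the scatter is expected in this assay, and the value is expected to sit near the limit. The estimate for compound 4 is 45000 nM, with a range from 18000 nM to 150000 nM. That estimate implies a step of an at least 1.1-fold lower number from compound 3 to compound 4 (0.04 log units; that floor lies within the scatter), which is expected to remain within the scatter.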

Compound 4, half-maximal inhibitory concentration: > 50000 nM
Compound 4 ended at the assay's limit (the forecaster's own chance of this, stated with the estimate: 55%); at least 1.1-fold (0.04 log units) between middle value and limit.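

In this assay compound 4 gives > 50000 nM, which is a limit of the assay and not a number. With chloro in place of methyl on this aromatic carbon, ortho to a large group and para to a chloro group, the 2,5-dichlorophenyl compound stays at the same limit as the 5-chloro-2-methylphenyl compound, so the series now holds two substituents at this carbon and neither brings a readable value, though the limit cannot separate them: the steps to compound 4 from compound 2 and compound 3 cannot be read, because both ends of each are limits: the limit of > 50000 nM in this assay, at which 3 of the 4 values shown sit. The one readable comparison is an at least 1.5-fold higher number from compound 1 to compound 4 (0.18 log units; that floor lies within the scatter), so chloro in place of hydrogen at this carbon is not shown to differ from the 3-chlorophenyl compound beyond the scatter.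

Going by these compounds, whether an amine or a hydroxyl group on this carbon would give a value under the limit stays open. Within the data shown here, with compound 1 at 32600 nM as the only number in the set, no direction of change on this ring can yet be read.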